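Substitution on the ring nitrogen of the pyrazoline-type core

This account rests on a few compounds, and the source may have more. Where it says the series, first, only, none or still open, it means among the compounds named here.

Compound 1 `CN1CCN(c2ccc(C3=NNC(c4ccc(N(C)C)cc4)C3)cc2)CC1` carries a hydrogen on the amine nitrogen in the ring and in a functional assay on HCC1806 cells (Homo sapiens) for inhibition, read by sulforhodamine B assay, tested at 10 uM (on this read-out higher numbers stand for more inhibition at the one concentration tested (going by the name of the read-out) and lower numbers for less inhibition), compound 1 gives 31.2%. Compound 2 `CN1CCN(c2ccc(C3=NN(C(=O)c4ccc(F)cc4)C(c4ccc(N(C)C)cc4)C3)cc2)CC1` carries a (4-fluorophenyl)carbonyl on that nitrogen instead, and in this assay compound 2 gives 31.8%. Going by the values given here, the step of a number 0.6 percentage points higher from compound 1 to compound 2 (within the scatter) is the only measured step, and it falls within the scatter; compound 2 and compound 1 therefore cannot be told apart on these numbers, and neither stands clear of the other.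

Compound 3 `Cc1ccc(S(=O)(=O)N2N=C(c3ccc(N4CCN(C)CC4)cc3)CC2c2ccc(N(C)C)cc2)cc1` is the next variation at the same position: (4-methylphenyl)sulfonyl in place of (4-fluorophenyl)carbonyl on an amine nitrogen in a ring. Among the compounds with values here, no measured step exchanges one substituent for another at that nitrogen; the only step that touches the position, a number 0.6 percentage points higher from compound 1 to compound 2 (within the scatter), shows that adding a (4-fluorophenyl)carbonyl there left the read-out unchanged beyond the scatter. On that basis a (4-methylphenyl)sulfonyl at the same place is expected to produce no step beyond the scatter either, so the estimated step is a number 0.2 percentage points higher from compound 2 to compound 3 (within the scatter). For compound 3 in this assay the expected value is 32%, with a range from 14% to 50%.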

Compound 3, a percentage reported as inhibition, at one concentration (the size of the read-out at that concentration, not a potency): 32.2%
For compound 3 the middle estimate is 0.2 percentage points below the measured one; low and high end bracket the measured number.
By their numbers in this assay, from the lowest: compounds 1, 2 and 3 (each within the scatter of the next).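

In this assay, going by these compounds alone, the exchange of (4-fluorophenyl)carbonyl for (4-methylphenyl)sulfonyl gives the first direct comparison of two substituents on the amine nitrogen in the ring, and the result is a number 0.4 percentage points higher from compound 2 to compound 3 (within the scatter). Set against the hydrogen of compound 1, the (4-methylphenyl)sulfonyl gives a number 1 percentage points higher from compound 1 to compound 3 (within the scatter), so a second substituent with a different linking group also cannot be told apart from the unsubstituted nitrogen, and compounds 1, 2 and 3 form a single group on this read-out. Nothing at hand offers an explanation for this lack of separation.

Going by these compounds, both substituents carry a six-membered aromatic ring of carbon only, so it remains open whether a group without such a ring, such as acetyl or a longer chain ending in an amine or a carboxylic acid, would shift the read-out at this nitrogen. Also open, on these data alone, is whether the 4-(dimethylamino)phenyl group on the ring atom next to this nitrogen, or the 4-methylpiperazinyl group at the other end of the molecule, has a larger bearing on the read-out.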